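A Swapped Substituent on a Thromboxane Receptor Antagonist

The source may report more compounds than this note shows. Statements on the series, on what has been measured and on what is new or still open speak of the compounds shown alone.

Three compounds have been measured:
compound 1 `CS(=O)(=O)Nc1cccc(-c2ccc(COC3CC[C@H](N4CCCCCC4)[C@H]3OC/C=C\CCC(=O)O)cc2)c1` gives 50.1 nM in a functional assay for antagonist activity at thromboxane A2 receptor (Rattus norvegicus); a higher number here means weaker binding, a lower number tighter binding;
compound 2 `O=C(O)CC/C=C\CO[C@H]1[C@@H](OCc2ccc(-c3ccc(CO)cc3)cc2)CC[C@@H]1N1CCCCCC1` gives 50.1 nM in this assay;
compound 3 `O=C(O)CC/C=C\CO[C@H]1[C@@H](OCc2ccc(-c3ccccc3)cc2)CC[C@@H]1N1CCCCC1` gives 31.6 nM; 50.1 nM (2 entries) in this assay.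

Compound 1 stands level with compound 2 at the digits shown, so the two lie within the usual scatter of each other. Compound 3 carries a different ring on the basic nitrogen and a plain phenyl on the biphenyl, and its repeated measurements the several entries of compound 3 in this assay, 31.6 nM; 50.1 nM (2 entries) show how much the same compound can move from one run to the next.

The new compound 4 `O=C(O)CC/C=C\CO[C@H]1C(OCc2ccc(-c3ccccc3CO)cc2)CC[C@@H]1N1CCCCCC1` keeps the shared core of compound 1 and differs only at one aromatic carbon: 2-(hydroxymethyl)phenyl in place of 3-(methanesulfonamido)phenyl on an aromatic carbon. For the measured compounds named here, no step between two measured compounds matches this change, so its size can only be guessed from the spread already seen. Compound 2, which also carries a hydroxymethyl group on its outer ring, sits where compound 1 does, and the step of a 1.3-fold higher number from compound 1 to compound 4 (0.10 log units; within the scatter) is expected to stay within the scatter, with no clear direction. Compound 4 is therefore estimated at 63 nM, within 20 nM to 200 nM.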

Compound 4, dissociation constant: 6.31 nM
For compound 4 the middle estimate is 10-fold (1.00 log units) above the measured one; measured number below the stated range.
By their numbers in this assay, from the lowest: compound 4; then compounds 1 and 2 (each within the scatter of the next).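

In this assay, the swap of 3-(methanesulfonamido)phenyl for 2-(hydroxymethyl)phenyl gives a 7.9-fold lower number from compound 1 to compound 4 (0.90 log units; beyond the scatter). For the compounds shown here, this is the first step that can be read directly, and it shows that the group on this aromatic carbon, para to a large group, can shift the number beyond the scatter while the shared core stays the same. The shift is also wider than the spread between repeat measurements of a single compound: the several entries of compound 3 in this assay, 31.6 nM; 50.1 nM (2 entries)

Two things changed together in this step, the group itself and where it sits on the outer ring, so the compounds shown cannot tell which of the two accounts for the lower number, or whether both contribute. A 2-(aminomethyl)phenyl group, which puts an amine where compound 4 has its alcohol, would test whether the hydroxymethyl group itself matters, and a 2-(methanesulfonamido)phenyl group would test the sulfonamide in the position used by compound 4, but neither is among the compounds shown here.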